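The compounds below may be only part of what the source reports. "The series", "measured", "known", "first", "only" and "open" are said of these compounds alone.

Among the compounds with values here, compound 2 `Cc1c(O)c(=O)ccn1CC(=O)N/N=C1\C(=O)N(CC(=O)Nc2ccccc2)c2ccccc21` stands at the higher of only two numbers so far measured in a functional assay on A549 cells (Homo sapiens) for cytotoxicity, read by MTT assay, with a stated time of 48 h (on this read-out lower numbers stand for an effect already at smaller amounts and higher numbers for an effect only at larger amounts of compound), where compound 2 gives 29200 nM. Within the data shown here, its single neighbour, compound 1 `Cc1c(O)c(=O)ccn1CC(=O)N/N=C1\C(=O)N(CC(=O)Nc2ccc(Cl)cc2)c2ccccc21`, gives 28300 nM in this assay, and the step of a 1.0-fold higher number from compound 1 to compound 2 (0.01 log units; within the scatter) shows that hydrogen in place of chloro on an aromatic carbon made no difference worth the name. Compound 3 `CC(=O)Nc1ccc(NC(=O)CN2C(=O)/C(=N\NC(=O)Cn3ccc(=O)c(O)c3C)c3ccccc32)cc1` differs from compound 2 by acetamido in place of hydrogen on an aromatic carbon. Among the measured compounds shown here, the one measured step bears on it only loosely: it concerns the same aromatic carbon, yet it swaps small groups, while acetamido is a larger group with a hydrogen-bond donor and acceptor. Nothing measured here speaks to such a group. The step from compound 2 to compound 3 is therefore expected to stay within the scatter, a 1.0-fold higher number from compound 2 to compound 3 (0.01 log units; within the scatter). Compound 3 is estimated at 30000 nM, within a range from 12000 nM to 75000 nM.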

Compound 3, half-maximal effective concentration: > 100000 nM
Compound 3: only a limit was reported; the forecaster's own chance of this, stated with the estimate: 10%; middle value at least 3.3-fold (0.52 log units) away from the limit.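

So this aromatic carbon is not indifferent to what it carries: in this assay acetamido in place of hydrogen gives a clear change (an at least 3.4-fold higher number from compound 2 to compound 3 (0.53 log units; beyond the scatter)), and acetamido in place of chloro gives one too (an at least 3.5-fold higher number from compound 1 to compound 3 (0.54 log units; beyond the scatter)). Chloro and hydrogen had stayed within the scatter of each other, so the earlier pair gave no sign that a group here could matter. Compound 3 sits at a limit of the assay rather than at a number, so both steps give only the smallest size the change can have: the limit of > 100000 nM in this assay, at which 1 of the 3 values shown sits.

Whether the size of acetamido, its hydrogen-bond donor or its acceptor goes with this change stays unsettled by a single group. As far as these compounds go, what an amine, a methoxy group or a longer amide chain on this same carbon would do also stays open.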